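Low efficacy amides at the thyrotropin receptor

The compounds below may be only part of what the source reports. "The series", "measured", "known", "first", "only" and "open" are said of these compounds alone.

Measured so far:
compound 1, `COc1cccc(-c2nc(SC)nc3sc(C(=O)N(C)C(C)(C)C)c(N)c23)c1`: 3.6%
compound 2, `COc1cccc(-c2nc(SC)nc3sc(C(=O)NN)c(N)c23)c1`: 6.1%
compound 3, `COc1cccc(-c2nc(SC)nc3sc(C(=O)NNC(C)(C)C)c(N)c23)c1`: 6.4%

In a functional assay on HEK293 cells for agonist activity at Thyrotropin receptor (Homo sapiens), read by cAMP accumulation (on this read-out lower numbers stand for smaller maximal responses and higher numbers for larger maximal responses), compound 3 gives 6.4%. This is the highest of the three numbers seen, but the gaps to the others are small: compound 2 lies a number 0.3 percentage points higher from compound 2 to compound 3 (within the scatter), and compound 1 lies a number 2.8 percentage points higher from compound 1 to compound 3 (within the scatter). All three values therefore sit in the same region, at the low end of the read-out, and the three compounds cannot be put in any order on this assay.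

Compound 4, `CCNC(=O)c1sc2nc(SC)nc(-c3cccc(OC)c3)c2c1N`, is the untested member of the series. It differs from compound 3 by ethyl in place of (tert-butyl)amino on an amide-type nitrogen.

Within the data shown here, no measured step replaces a hydrazide-type substituent with a simple alkyl group, so none bears directly on this change. The closest comparisons are the three steps among compounds 1, 2 and 3, which vary the same carbonyl substituent and all stay within the scatter: a number 2.5 percentage points higher from compound 1 to compound 2 (within the scatter), a number 2.8 percentage points higher from compound 1 to compound 3 (within the scatter) and a number 0.3 percentage points higher from compound 2 to compound 3 (within the scatter). Every variation of this substituent seen so far has left the maximal response near the floor of the assay.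

Compound 4 is therefore expected to behave in the same way, with an estimated step of a number 1.4 percentage points lower from compound 3 to compound 4 (within the scatter), meaning no change beyond the scatter. The estimate for compound 4 is 5%, with a range from 0% to 14%.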

Compound 4, largest response reached (reported as efficacy), in percent of the reference or control that the assay uses: 2.3%
Compound 4: the middle estimate sits 2.7 percentage points above what was measured; the measured number falls inside the stated range.
By their numbers in this assay, from the lowest: compounds 4, 1, 2 and 3 (each within the scatter of the next).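

In this assay, putting ethyl on the amide-type nitrogen does not move the response beyond the scatter, whether it replaces (tert-butyl)amino, a number 4.1 percentage points lower from compound 3 to compound 4 (within the scatter), or amino, a number 3.8 percentage points lower from compound 2 to compound 4 (within the scatter). Among these compounds, the same holds for ethylamino in place of methyl(tert-butyl)amino on the carbonyl carbon, a number 1.3 percentage points lower from compound 1 to compound 4 (within the scatter), so a plain alkyl group with no amino group on the amide-type nitrogen now joins the hydrazide-type and tertiary amide substituents of the earlier compounds, and all four compounds sit together at the low end of the read-out. Nothing independent of this read-out is available to explain why the response stays there.

On these data alone, what remains open is whether any substituent at this carbonyl carbon can lift the response clear of this region, for example a longer chain such as n-hexylamino, a benzylamino group or a free carboxylic acid in place of the amide. Also open, as far as these compounds go, is whether the response depends on the rest of the shared core, such as the methoxy group on its aryl ring or the free amine, rather than on this amide.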